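The source may hold more compounds than are shown below. What is called first, only, known or untested is meant among the compounds shown, and "the series" means these compounds.

Of the compounds shown here, three that share one core have been tested in a functional assay on MDBK cells (Bos taurus) for cytotoxicity; on this read-out lower numbers stand for higher toxicity in this test and higher numbers for lower toxicity in this test. Compound 1 `CO/N=C(\C#N)C(=O)NCC1=NOC(C)(C)C1` gives > 100 ug/mL, which is a limit of the assay and not a number. Going by the values given here, compound 2 `C=CCO/N=C(\C#N)C(=O)NCC1=NOC(c2ccccc2)C1` gives 100 ug/mL, the only true number among the three. Compound 3 `CCO/N=C(\C#N)C(=O)NCC1=NOC(C(C)(C)C)C1` gives > 100 ug/mL, again a limit of the assay. Compound 3 thus stands at the limit of > 100 ug/mL in this assay, at which 2 of the 3 values shown sit.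

Compound 4 `CC(C)(C)C1CC(CNC(=O)/C(C#N)=N/OCc2cccnc2)=NO1` has not yet been measured. Its structure differs from that of compound 3 by pyridin-3-yl in place of methyl on a saturated chain carbon bound to an oxygen on an unsaturated carbon, on a saturated chain carbon bound to an oxygen on an unsaturated carbon. Cut one bond further out, the same difference reads ethoxy to (pyridin-3-yl)methoxy.

Among the compounds with values here, no pair of measured compounds differs in one place only, so this assay shows no direct size for such a change. Within the data shown here, the expectation therefore leans on compound 2, which gives 100 ug/mL and is the only compound with a true number. The estimated step of a number no higher from compound 3 to compound 4 (the limit leaves the size open) is expected to stay within the usual scatter, with any drift towards lower numbers. For compound 4 the expected value is 100 ug/mL, with an estimated range from 40 ug/mL to 200 ug/mL.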

Compound 4, half-maximal cytotoxic concentration: > 100 ug/mL
Compound 4: no number, only a limit (the forecaster's own chance of this, stated with the estimate: 70%); the middle value lies on the limit itself.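

In this assay compound 4 gives > 100 ug/mL, which is a limit of the assay and not a number. Compound 3 also stands at a limit, and the step between compound 3 and compound 4 cannot be read. The compounds shown leave open whether (pyridin-3-yl)methoxy in place of ethoxy changes this read-out at all.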